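Butyl in Place of Nitrophenyl on a Weak Series

This account rests on a few compounds, and the source may have more. Where it says the series, first, only, none or still open, it means among the compounds named here.

Compound 1 `CSc1ccc(Cc2nn(-c3ccccc3)c(=O)c3ccccc23)cc1` gives > 100000 nM in a functional assay on aorta with Alpha-1D adrenergic receptor (Rattus norvegicus) as the target (a lower number here means that less compound is needed, a higher number that more compound is needed for the effect), which is a limit of the assay and not a number.
Compound 2 `O=c1c2ccccc2c(Cc2ccc(Cl)cc2)nn1-c1ccc([N+](=O)[O-])cc1` gives 29000 nM in this assay.
Compound 3 `CSc1ccc(Cc2nn(-c3ccc([N+](=O)[O-])cc3)c(=O)c3ccccc23)cc1` gives > 100000 nM in this assay, again a limit and not a number.

Going by the values given here, compound 2 therefore stands as the only real number among the three values; the other two sit at the limit of > 100000 nM in this assay, at which 2 of the 3 values shown sit. Compound 4 `CCCCn1nc(Cc2ccc(Cl)cc2)c2ccccc2c1=O` differs from compound 2 by butyl in place of 4-nitrophenyl on an aromatic nitrogen. Two measured steps exist. The step of an at least 3.4-fold higher number from compound 2 to compound 3 (0.53 log units; beyond the scatter) concerns the benzyl side and does not touch the place that changes here. The step that the two limits leave unreadable from compound 1 to compound 3 does touch the group that leaves, but both ends are limits, so it gives no readable size. Among the compounds with values here, no measured step therefore bears directly on the exchange of the whole 4-nitrophenyl for butyl, and no direction can be expected with confidence. Compound 4 is estimated at 40000 nM, within 8000 nM to 200000 nM, which would mean an expected step of a 1.4-fold higher number from compound 2 to compound 4 (0.14 log units; within the scatter).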

Compound 4, half-maximal effective concentration: > 100000 nM
Compound 4 gave a limit, no number; the forecaster's own chance of this, stated with the estimate: 40%; at least 2.5-fold (0.39 log units) between middle value and limit.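

Butyl in place of 4-nitrophenyl on the aromatic nitrogen gave an at least 3.4-fold higher number from compound 2 to compound 4 (0.53 log units; beyond the scatter) in this assay, the first readable step at this position, as the earlier step at this group had two limits at its ends and could not be read. The value of compound 4, > 100000 nM, is a limit of the assay and not a number. With the 4-chlorobenzyl group held in place, the group on this nitrogen therefore counts for the result, and compound 2 remains the only compound with a real number: the limit of > 100000 nM in this assay, at which 3 of the 4 values shown sit.

From the compounds shown here alone, it remains open whether the six-membered ring of the 4-nitrophenyl group or its nitro group carries the difference, which a plain phenyl beside the 4-chlorobenzyl group would help to separate. Going by these compounds, it is equally open whether a longer chain or a chain ending in an amine on this nitrogen would give a readable number.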